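Extending compound 1 toward a substituted aminopyrimidine position

The source may report more compounds than this note shows. Statements on the series, on what has been measured and on what is new or still open speak of the compounds shown alone.

Measured compounds:
compound 1 `C[C@@H]1CCCN1c1c(C#N)c2c(N)ncnc2n1C`: 0.7 nM
compound 2 `Cn1c(N)c(C#N)c2c(N)ncnc21`: 589 nM

Of the compounds shown here, two have been measured in an assay on isolated protein for binding affinity to Leucine-rich repeat serine/threonine-protein kinase 2 variant G2019S (Homo sapiens), read by TR-FRET and LanthaScreen, with a stated time of 2 h; a lower number here means a stronger inhibitor, a higher number a weaker inhibitor. Compound 1 gives 0.7 nM, the lowest of the two numbers; compound 2, which carries an amino group in place of the 2-methylpyrrolidin-1-yl group, gives 589 nM. Within the data shown here, the only measured step is an 840-fold higher number from compound 1 to compound 2 (2.93 log units; beyond the scatter), a large change that concerns the 2-methylpyrrolidin-1-yl group alone.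

Compound 3 `C[C@@H]1CCCN1c1c(C#N)c2c(N)nc(Nc3cnn(C)c3)nc2n1C` keeps everything that compound 1 has and differs in one place: (1-methyl-1H-pyrazol-4-yl)amino in place of hydrogen on an aromatic carbon. Among the measured compounds shown here, no measured step touches this position, so the one step on record, from compound 1 to compound 2, says nothing about what the new group will do, and no size of step can be inferred from it. Compound 1 already sits at a low number in this assay, which leaves little room for a further drop. The expectation for compound 3 is therefore a number close to that of compound 1, with the step of a 1.2-fold lower number from compound 1 to compound 3 (0.07 log units; within the scatter) estimated to stay within the scatter. Compound 3 is estimated at 0.6 nM, in a range from 0.15 nM to 3 nM.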

Compound 3, inhibition constant: 0.3 nM
For compound 3 the middle estimate is 2.0-fold (0.30 log units) above the measured one; the measured number falls inside the stated range.
By their numbers in this assay, from the lowest: compound 3; then compound 1; then compound 2.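

The position between two ring nitrogen atoms, which neither earlier compound varied, takes a substituent in this assay without loss: placing (1-methyl-1H-pyrazol-4-yl)amino there in place of hydrogen gives a 2.3-fold lower number from compound 1 to compound 3 (0.37 log units; beyond the scatter) and this modest step lies beyond the scatter. Among these compounds, the first measured change at this position thus adds 7 heavy atoms, including a five-membered aromatic ring, and still moves the number lower from a starting point that was already low. This remains a single step at one position, and no available evidence accounts for its direction or size.

What the compounds shown leave open is which part of the new group matters, the amino link or the 1-methyl-1H-pyrazol-4-yl ring, and a plain amino group, a methylamino group or a phenylamino group at the same position would help to separate the two. Also open, from the compounds shown here alone, is whether the new group would have a comparable effect with an amino group in place of the 2-methylpyrrolidin-1-yl group, the change that separates compound 2 from compound 1.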